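Series notes: the step from compound 3 to compound 4

This account rests on a few compounds, and the source may have more. Where it says the series, first, only, none or still open, it means among the compounds named here.

Measured so far in a functional assay on HCT-116 cells (Homo sapiens) for inhibition; on this read-out higher numbers stand for weaker inhibition and lower numbers for stronger inhibition 
- compound 1 `CC(=O)N[C@@H](CCC(=O)NCCC(COCc1ccccc1)COCc1ccccc1)C(=O)N[C@@H](CC(C)C)B1O[C@@H]2C[C@@H]3C[C@@H](C3(C)C)[C@]2(C)O1` gives 110 nM 
- compound 2 `CC(=O)N[C@@H](CCC(=O)NCCCC(COCc1ccccc1)COCc1ccccc1)C(=O)N[C@@H](CC(C)C)B1O[C@@H]2C[C@@H]3C[C@@H](C3(C)C)[C@]2(C)O1` gives 67.2 nM 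
- compound 3 `CC(C)C[C@H](NC(=O)[C@H](CC(=O)NCCC(COCc1ccccc1)COCc1ccccc1)NC(=O)c1cc(Cl)ccc1Cl)B1O[C@@H]2C[C@@H]3C[C@@H](C3(C)C)[C@]2(C)O1` gives 140 nM 

The number for compound 3 lies within the scatter of the number for compound 1 and stands just beyond the scatter above the number for compound 2. Compound 4 `CC(C)C[C@H](NC(=O)[C@H](CC(=O)NCCC(COCc1ccccc1)COCc1ccccc1)NC(=O)c1ccccc1)B1O[C@@H]2C[C@@H]3C[C@@H](C3(C)C)[C@]2(C)O1` has not yet been measured. Its structure departs from that of compound 3 by phenyl in place of 2,5-dichlorophenyl on a carbonyl carbon and this amounts to phenyl in place of 2,5-dichlorophenyl on a carbonyl carbon. Within the data shown here, no measured pair isolates this change, so direct evidence for it is lacking. Compound 1 and compound 3 differ in more than one place, yet their values stay within the scatter of each other. The value of 140 nM for compound 3 is therefore the anchor for the expectation. The estimated 1.2-fold higher number from compound 3 to compound 4 (0.08 log units; within the scatter) is slightly towards a higher number and stays within the scatter. For compound 4 the expected value is 170 nM with an estimated range from 70 nM to 400 nM in this assay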

Compound 4, half-maximal inhibitory concentration: 60 nM
Beside the measured number, compound 4's estimate is 2.8-fold (0.45 log units) above it; the whole stated range lies above it.
By their numbers in this assay, from the lowest: compounds 4, 2, 1 and 3 (each within the scatter of the next, the first and the last beyond it).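

In this assay, among these compounds, phenyl in place of 2,5-dichlorophenyl on a carbonyl carbon gives a 2.3-fold lower number from compound 3 to compound 4 (0.37 log units; beyond the scatter), a modest step and the first direct reading of a single change at this place. The two chlorine atoms are therefore not needed for inhibition here, and the unsubstituted benzoyl group gives the stronger inhibition of this pair. No data at hand explain the step.

The pair cannot show whether the loss of one chlorine atom or of both accounts for the step, and a single chlorine on the phenyl ring would separate these cases. It also leaves open how a methoxy group on the phenyl ring, or a pyridine ring in its place, would read at this carbonyl carbon.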